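The source may report more compounds than this note shows. Statements on the series, on what has been measured and on what is new or still open speak of the compounds shown alone.

Measured so far in an assay on isolated protein for displacement of a labelled ligand from metabotropic glutamate receptor 5 (Homo sapiens), with a stated time of 60 min, tested at 1 uM; a higher number here means more inhibition at the concentration tested (going by the name of the read-out), a lower number less inhibition:
compound 1 `Cc1ccc(S(=O)(=O)c2cnc3ccc(Cl)cc3c2N2CCC(C)CC2)cc1`, 95%
compound 2 `CC1CCN(c2c(S(=O)(=O)c3ccc(C#N)cc3)cnc3ccc(Cl)cc23)CC1`, 31%
compound 3 `Cc1cc(C)cc(S(=O)(=O)c2cnc3ccc(Cl)cc3c2N2CCC(C)CC2)c1`, 49%

Compound 3 stands second of the three: its nearest neighbour is compound 2, with a step of a number 18 percentage points higher from compound 2 to compound 3 (beyond the scatter), and the furthest is compound 1, with a step of a number 46 percentage points lower from compound 1 to compound 3 (beyond the scatter). Both steps lie beyond the scatter.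

Compound 4 `CC1CCN(c2c(S(=O)(=O)c3ccc(Cl)cc3)cnc3ccc(Cl)cc23)CC1` is not yet measured. Its change from compound 3 is 4-chlorophenyl in place of 3,5-dimethylphenyl on a sulfonyl sulfur. Among the measured compounds shown here, two measured steps touch the same place on the sulfonyl sulfur: a number 46 percentage points lower from compound 1 to compound 3 (beyond the scatter) and a number 18 percentage points higher from compound 2 to compound 3 (beyond the scatter), and a third, a number 64 percentage points lower from compound 1 to compound 2 (beyond the scatter), shows how strongly the group on the aromatic carbon of that ring moves the read-out. Compound 1 and compound 2 bracket the 4-substituted ring from high to low; compound 3 sits between them. A 4-chlorophenyl is thus expected to land somewhere within that bracket, most likely above compound 3, as a modest rise a number 16 percentage points higher from compound 3 to compound 4 (beyond the scatter), though with wide uncertainty given the size of a number 64 percentage points lower from compound 1 to compound 2 (beyond the scatter). Compound 4 is therefore estimated at 65%, between 35% and 90%.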

Compound 4, a percentage reported as inhibition, at one concentration (the size of the read-out at that concentration, not a potency): 92%
Beside the measured number, compound 4's estimate is 27 percentage points below it; the whole stated range lies below it.
By their numbers in this assay, from the lowest: compound 2; then compound 3; then compounds 4 and 1 (each within the scatter of the next).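

In this assay, the group on the aromatic carbon of the ring on the sulfonyl sulfur now has three members: chloro in place of cyano gives a large rise (a number 61 percentage points higher from compound 2 to compound 4 (beyond the scatter)), whereas chloro in place of methyl leaves the read-out within the scatter (a number 3 percentage points lower from compound 1 to compound 4 (within the scatter)). Among these three compounds, only the nitrile of compound 2 stands apart from the other two, and 4-chlorophenyl in place of 3,5-dimethylphenyl (a number 43 percentage points higher from compound 3 to compound 4 (beyond the scatter)) shows that compound 3 also lies well below both compound 1 and compound 4. No evidence is available on what underlies these differences.

As far as these compounds go, whether a methoxy group or a fluorine on that aromatic carbon would read with chloro and methyl or with the nitrile stays open. So does the read-out of an unsubstituted phenyl on the sulfonyl sulfur.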